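The compounds below may be only part of what the source reports. "The series", "measured", "known", "first", "only" and "open" are said of these compounds alone.

Compound 1 `O=C(/C=C/CN1CC(Oc2ccc(Oc3c(-c4ccc(F)cc4)sc4cc(O)ccc34)cc2)C1)N1CCCC1`: in a functional assay on Ishikawa cells (Homo sapiens) for antiproliferative activity, read by CCK-8 assay, with a stated time of 48 h (a lower number here means a stronger inhibitor, a higher number a weaker inhibitor), compound 1 gives 9150 nM.
Compound 2 `O=C(CCCNCCOc1ccc(Oc2c(-c3ccc(F)cc3)sc3cc(O)ccc23)cc1)N1CCC1`: in this assay compound 2 gives only > 25000 nM, which is a limit of the assay and not a number.

Compound 2 therefore stands at the limit of > 25000 nM in this assay, at which 1 of the 2 values shown sits, and nothing more precise is known about it. Compound 3 `CN(C)C(=O)/C=C/CN1CC(Oc2ccc(Oc3c(-c4ccc(F)cc4)sc4cc(O)ccc34)cc2)C1` has not yet been measured. It differs from compound 2 in one place: 1-(3-(dimethylcarbamoyl)prop-2-en-1-yl)azetidin-3-yl in place of 2-((3-((azetidin-1-yl)carbonyl)propyl)amino)ethyl on an oxygen on an aromatic ring. Among the measured compounds shown here, no step between two measured compounds is available to calibrate this change, so its size can only be expected. The step of an at least 2.5-fold lower number from compound 2 to compound 3 (0.39 log units; beyond the scatter) is expected to be a gain beyond the usual scatter, moving compound 3 from the limit into the range where a number can be read. The reference for that range is compound 1, which gives 9150 nM in this assay. Compound 3 is estimated at 10000 nM, within 3000 nM to 30000 nM.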

Compound 3, half-maximal inhibitory concentration: 11200 nM
Compound 3: middle estimate off by 1.1-fold (0.05 log units), on the low side, within the range that was stated.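

In this assay, 1-(3-(dimethylcarbamoyl)prop-2-en-1-yl)azetidin-3-yl in place of 2-((3-((azetidin-1-yl)carbonyl)propyl)amino)ethyl on the oxygen gives an at least 2.2-fold lower number from compound 2 to compound 3 (0.34 log units; beyond the scatter), so this exchange brings a readable value. As far as these compounds go, compound 2 remains a limit of the assay and not a number, so the true size of that step stays unknown: the limit of > 25000 nM in this assay, at which 1 of the 3 values shown sits. On the carbonyl carbon, dimethylamino in place of pyrrolidin-1-yl gives a 1.2-fold higher number from compound 1 to compound 3 (0.09 log units; within the scatter), so these two amide ends cannot be told apart here.

The compounds shown leave open which part of the larger exchange matters: the added double bond, the lost hydrogen-bond donor or the changed azetidine ring. They also leave open how a piperidin-1-yl or morpholin-4-yl group on that carbonyl carbon would read.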